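The compounds below may be only part of what the source reports. "The series", "measured", "known", "first", "only" and "open" are said of these compounds alone.

Three members of the series carry a substituted phenyl on an aromatic nitrogen of the shared core. Compound 1 `COc1ccccc1-n1cc(COc2c(/C=C\C(=O)O)ccc(OC)c2CC=C(C)C)nn1` gives 32200 nM in a functional assay on HCT-116 cells (Homo sapiens) for cytotoxicity, read by MTT assay, with a stated time of 24 h; a lower number here means a stronger inhibitor, a higher number a weaker inhibitor. Compound 2 `COc1ccc(/C=C\C(=O)O)c(OCc2cn(-c3ccccc3I)nn2)c1CC=C(C)C` gives 23100 nM and compound 3 `COc1ccc(/C=C\C(=O)O)c(OCc2cn(-c3ccc(C#N)cc3)nn2)c1CC=C(C)C` gives 21000 nM. Compound 3 holds the lowest of the three numbers, but the separation is small: a 1.5-fold lower number from compound 1 to compound 3 (0.19 log units; within the scatter) and a 1.1-fold lower number from compound 2 to compound 3 (0.04 log units; within the scatter). Compound 4 `COc1ccc(/C=C\C(=O)O)c(OCc2cn(-c3cccc([N+](=O)[O-])c3)nn2)c1CC=C(C)C` differs from compound 3 by 3-nitrophenyl in place of 4-cyanophenyl on an aromatic nitrogen. The two steps that change the group on this nitrogen, from compound 1 and from compound 2 to compound 3, both stayed within the scatter, so no step beyond the scatter is expected in this assay, in either direction. Compound 4 is therefore estimated at 24000 nM, with a range of 11000 nM to 52000 nM; the expected step is a 1.1-fold higher number from compound 3 to compound 4 (0.06 log units; within the scatter).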

Compound 4, half-maximal inhibitory concentration: 27300 nM
For compound 4 the middle estimate is 1.1-fold (0.06 log units) below the measured one, within the range that was stated.
By their numbers in this assay, from the lowest: compounds 3, 2, 4 and 1 (each within the scatter of the next).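

In this assay the 3-nitrophenyl group on the aromatic nitrogen stays within the scatter of 4-cyanophenyl (a 1.3-fold higher number from compound 3 to compound 4 (0.11 log units; within the scatter)), 2-iodophenyl (a 1.2-fold higher number from compound 2 to compound 4 (0.07 log units; within the scatter)) and 2-methoxyphenyl (a 1.2-fold lower number from compound 1 to compound 4 (0.07 log units; within the scatter)). The four substituted phenyl groups at this position therefore cannot be ranked, and a nitro group reads no differently here from a nitrile, an iodo or a methoxy group. Nothing shown gives a reason for this flat result.

As far as these compounds go, whether an amine on the phenyl ring, or a longer alkyl chain in place of the phenyl, would move the number beyond the scatter remains open.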